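A (4-Methylphenyl)sulfonyl Ester in Place of Vinylcarbonyl

A few compounds are considered here, and "the series" means these few. Any claim that something is new, unique, unknown or untested is made for them only; others in the source may bear on it.

Compound 2 `C=CC(=O)Oc1cc(/C=C/C(=O)c2ccc(OC)c3c2OC(C)(C)C=C3)ccc1OC` stands lowest of the two numbers measured in a functional assay on K562 cells (Homo sapiens) for cytotoxicity, read by MTT assay; on this read-out higher numbers stand for weaker inhibition and lower numbers for stronger inhibition; compound 2 gives 300 nM. Compound 3 `COc1cccc(C(=O)Oc2cc(/C=C/C(=O)c3ccc(OC)c4c3OC(C)(C)C=C4)ccc2OC)c1` gives 790 nM in this assay. The gap between them is a 2.6-fold higher number from compound 2 to compound 3 (0.42 log units; beyond the scatter). Compound 1 `C#CCOc1cc(/C=C/C(=O)c2ccc(OC)c3c2OC(C)(C)C=C3)ccc1OC` reaches only a limit in this assay, > 10000 nM, and the limit of > 10000 nM in this assay, at which 1 of the 3 values shown sits, marks the boundary of what was measured. The two large steps leaving compound 1 are an at least 33-fold lower number from compound 1 to compound 2 (1.52 log units; beyond the scatter) and an at least 12-fold lower number from compound 1 to compound 3 (1.10 log units; beyond the scatter); both replace propargyl with an acyl group, and both are well beyond the scatter.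

Compound 4 `COc1ccc(/C=C/C(=O)c2ccc(OC)c3c2OC(C)(C)C=C3)cc1OS(=O)(=O)c1ccc(C)cc1` differs from compound 2 as follows: (4-methylphenyl)sulfonyl in place of vinylcarbonyl on an oxygen on an aromatic ring. Among the compounds with values here, the entering group carries an aromatic ring on the phenolic oxygen, as compound 3 does, and the only measured step that bears on adding such a ring is a 2.6-fold higher number from compound 2 to compound 3 (0.42 log units; beyond the scatter), a modest rise. A step of similar size and direction in this assay is therefore expected for compound 4, a 2.7-fold higher number from compound 2 to compound 4 (0.43 log units; beyond the scatter). Compound 4 is estimated at 800 nM, with a range from 250 nM to 3000 nM.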

Compound 4, half-maximal inhibitory concentration: 7850 nM
Compound 4: the middle estimate sits 9.8-fold (0.99 log units) below what was measured; measured number above the stated range.
By their numbers in this assay, from the lowest: compound 2; then compound 3; then compound 4. At a limit, above all of these: compound 1.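

The sulfonyl ester breaks with the two carbonyl esters at this oxygen on an aromatic ring. Putting (4-methylphenyl)sulfonyl in place of vinylcarbonyl gives a 26-fold higher number from compound 2 to compound 4 (1.42 log units; beyond the scatter) as a large step. Putting (4-methylphenyl)sulfonyl in place of (3-methoxyphenyl)carbonyl, the ester that also carries an aromatic ring, gives a 9.9-fold higher number from compound 3 to compound 4 (1.00 log units; beyond the scatter) as a modest step. An aromatic ring on this oxygen therefore does not set the level on its own, and what enters with it matters far more than compound 3 alone suggested. Putting (4-methylphenyl)sulfonyl in place of propargyl reads only as a floor, an at least 1.2-fold lower number from compound 1 to compound 4 (0.10 log units; that floor lies within the scatter) and sets no order between those two compounds. The value of compound 1 is a limit and not a number: the limit of > 10000 nM in this assay, at which 1 of the 4 values shown sits.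

The compounds shown do not separate the sulfonyl link from the 4-methylphenyl group, as compound 3 differs from compound 4 in both. From the compounds shown here alone, whether a methylsulfonyl group on this oxygen would stay near compound 4, or an acetyl group near compound 2, remains open.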